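A few compounds are considered here, and "the series" means these few. Any claim that something is new, unique, unknown or untested is made for them only; others in the source may bear on it.

Of the compounds shown here, three have values so far. In an ADME assay on microsomes from liver (Homo sapiens) for metabolic stability, read by LC-MS, using NADPH, with stated times of 5 min and 30 min, tested at 1 uM (a lower number here means slower removal, a higher number faster removal of the compound), compound 1 (`CN(c1ncco1)c1cnc(NCc2c(F)ccc3c2CCO3)n2cnnc12`) gives 11 mL.min-1.g-1, compound 2 (`Cc1nccn1-c1cnc(NCc2c(F)ccc3c2CCO3)c2cn[nH]c(=O)c12`) gives 8 mL.min-1.g-1 and compound 3 (`Cn1nccc1-c1cnc(NCc2c(F)ccc3c2CCO3)c2cn[nH]c(=O)c12`) gives 14 mL.min-1.g-1. Compound 1 lies within the scatter of both others, so it holds no distinct place among the three.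

Compound 4 (`C[C@@H]1CC(=O)N(c2cnc(NCc3c(F)ccc4c3CCO4)n3cnnc23)C1`) has not yet been measured in this assay. It keeps the core of compound 1 and differs in one group: 4-methyl-2-oxopyrrolidin-1-yl in place of methyl(1,3-oxazol-2-yl)amino on an aromatic carbon. In words, 4-methyl-2-oxopyrrolidin-1-yl stands in place of methyl(1,3-oxazol-2-yl)amino on an aromatic carbon, and the entering group brings a defined stereocentre.

Within the data shown here, only one measured exchange at a single place is available, and it bears on this change only loosely: a 1.8-fold higher number from compound 2 to compound 3 (0.24 log units; within the scatter). There, 1-methyl-1H-pyrazol-5-yl replaces 2-methyl-1H-imidazol-1-yl, so neither group of the present change is involved. Among the measured compounds shown here, no measured compound other than compound 1 shares this exchange site with compound 4, and the data give no direction for the change. The estimate therefore stays close to compound 1 at 11 mL.min-1.g-1, and the step expected is a 1.1-fold higher number from compound 1 to compound 4 (0.04 log units; within the scatter), none beyond the scatter. For compound 4 the estimated value is 12 mL.min-1.g-1, with an expected range from 6 mL.min-1.g-1 to 24 mL.min-1.g-1.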

Compound 4, intrinsic clearance in microsomes: < 3 mL.min-1.g-1
Compound 4 ended at the assay's limit (the forecaster's own chance of this, stated with the estimate: 3%); middle value at least 4.0-fold (0.60 log units) from the limit.
By their numbers in this assay, from the lowest: compounds 2, 1 and 3 (each within the scatter of the next). At a limit, below all of these: compound 4.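

In this assay compound 4 gives < 3 mL.min-1.g-1, which is a limit of the assay and not a number. Among these compounds, on this aromatic carbon, para to a large group, 4-methyl-2-oxopyrrolidin-1-yl in place of methyl(1,3-oxazol-2-yl)amino, with no change in the count of heavy atoms, gives an at least 3.6-fold lower number from compound 1 to compound 4 (0.56 log units; beyond the scatter), so this position does respond to the exchange, whereas the one earlier step, made on a different core, showed a 1.8-fold higher number from compound 2 to compound 3 (0.24 log units; within the scatter). The step is therefore a bound and not a full measure, and its true size remains unknown: the limit of < 3 mL.min-1.g-1 in this assay, at which 1 of the 4 values shown sits.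

The exchange replaces a five-membered aromatic ring with a five-membered non-aromatic ring, removes the linking nitrogen bearing a methyl, adds a carbonyl and brings a defined stereocentre, and this single pair cannot show which of these differences matters. On these data alone, it also remains open whether plain 2-oxopyrrolidin-1-yl, the opposite stereoisomer of the 4-methyl group or an open-chain N-methylacetamido group would give a similar result on the core of compound 1.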